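Changing One Side Group on Compound 1

This account rests on a few compounds, and the source may have more. Where it says the series, first, only, none or still open, it means among the compounds named here.

In an ADME assay on Vero cells (Chlorocebus sabaeus) for cytotoxicity, read by fluorescence, with a stated time of 4 days (on this read-out higher numbers stand for weaker inhibition and lower numbers for stronger inhibition), compound 1 `COc1cc2c(cc1OC)CN(S(=O)(=O)c1ccc(-n3cc(COc4ccc([N+](=O)[O-])cc4)nn3)cc1)CC2` gives > 50000 nM as its result, and that is a limit of the assay, not a number. This places compound 1 at the limit of > 50000 nM in this assay, at which 1 of the 2 values shown sits, in the data so far. Compound 2 `O=c1cc(OCc2cn(-c3ccc(S(=O)(=O)N4CCc5ccccc5C4)cc3)nn2)c2ccccc2o1` does give a true number in this assay and reads 28600 nM there.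

Compound 3 `COc1cc2c(cc1OC)CN(S(=O)(=O)c1ccc(-n3cc(COc4cc(C=O)ccc4OC)nn3)cc1)CC2` keeps the core of compound 1 and changes one group: 5-formyl-2-methoxyphenyl in place of 4-nitrophenyl on an oxygen on a saturated carbon while the rest stays the same. For the measured compounds named here, no measured pair shows what such a swap does in this assay so only a modest expectation is fair: a small move toward stronger inhibition, or none beyond the usual scatter. Going by the values given here, the expectation leans on compound 2 and its reading of 28600 nM as the only true number available. The estimated change is an at least 1.2-fold lower number from compound 1 to compound 3 (0.09 log units; that floor lies within the scatter) and the assay may again report only a limit. For compound 3 the expected value is 40000 nM with an estimated range from 15000 nM to 70000 nM around it.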

Compound 3, half-maximal inhibitory concentration: > 50000 nM
Compound 3: a limit, no number; the forecaster's own chance of this, stated with the estimate: 50%; at least 1.2-fold (0.09 log units) between middle value and limit.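

In this assay compound 3 gives > 50000 nM as a limit and not a number. Compound 1 also stands at a limit, so no step can be read from compound 1 to compound 3. The compounds shown leave open whether 5-formyl-2-methoxyphenyl in place of 4-nitrophenyl changes the cytotoxicity reading at all.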